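Trimming the Pyrrolidine Acid Down to a Hydroxyl

The source may hold more compounds than are shown below. What is called first, only, known or untested is meant among the compounds shown, and "the series" means these compounds.

Compound 1 `COc1ccc(/C=C\c2cc(OC)c(OC)c(OC)c2)cc1OCc1ccc(CN2C[C@H](O)C[C@@H]2C(=O)O)cc1` gives in a functional assay on HeLa cells (Homo sapiens) for antiproliferative activity, read by CCK-8 assay, with a stated time of 48 h (on this read-out higher numbers stand for weaker inhibition and lower numbers for stronger inhibition), only a limit, > 10000 nM.
Compound 2 `COc1ccc(/C=C\c2cc(OC)c(OC)c(OC)c2)cc1OCc1ccc(CN2CC[C@@H](C(=O)O)C2)cc1` gives in this assay 12800 nM.
Compound 3 `COc1ccc(/C=C\c2cc(OC)c(OC)c(OC)c2)cc1OCc1ccc(C=O)cc1` gives in this assay 4800 nM.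

Compound 1 stands at the limit of this assay, so its number is not known; the evidence the limit of > 10000 nM in this assay, at which 1 of the 3 values shown sits, shows that it is the only one of the three to sit there. Compound 4 `COc1ccc(/C=C\c2cc(OC)c(OC)c(OC)c2)cc1OCc1ccc(CO)cc1` is compound 1 with a far smaller group at the same place: hydroxy in place of 2-carboxy-4-hydroxypyrrolidin-1-yl on a saturated chain carbon bound to an aromatic carbon. Going by the values given here, the steps that bear on this are those toward compound 3, where a small formyl group replaces the large ring-bearing groups: an at least 2.0-fold lower number from compound 1 to compound 3 (0.31 log units; beyond the scatter) and a 2.7-fold lower number from compound 2 to compound 3 (0.43 log units; beyond the scatter). The step that the limit leaves unreadable from compound 1 to compound 2 cannot be sized because compound 1 sits at the limit. Both readable steps go in the same direction, toward a lower number when the ring-bearing group is removed, and compound 4 carries a small group much as compound 3 does. The number for compound 4 is therefore expected to drop by about an at least 2.0-fold lower number from compound 1 to compound 4 (0.30 log units; that floor lies within the scatter) in this assay. Compound 4 is estimated at 5000 nM, between 1500 nM and 15000 nM.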

Compound 4, half-maximal inhibitory concentration: 7600 nM
Estimate against measurement, compound 4: 1.5-fold (0.18 log units) below; measured number inside the range.
By their numbers in this assay, from the lowest: compounds 3, 4 and 2 (each within the scatter of the next, the first and the last beyond it).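

Hydroxy in place of 2-carboxy-4-hydroxypyrrolidin-1-yl gives an at least 1.3-fold lower number from compound 1 to compound 4 (0.11 log units; that floor lies within the scatter), but this step has only a floor and cannot be sized, because compound 1 sits at a limit of this assay: the limit of > 10000 nM in this assay, at which 1 of the 4 values shown sits.

The readable steps add something new: hydroxymethyl in place of formyl gives a 1.6-fold higher number from compound 3 to compound 4 (0.20 log units; within the scatter), so at this place a formyl carbonyl is not needed to keep the number in this range. Hydroxy in place of 3-carboxypyrrolidin-1-yl gives a 1.7-fold lower number from compound 2 to compound 4 (0.23 log units; within the scatter), so compound 4 goes against any simple rule that a small group here always beats a ring-bearing one, since it cannot be told apart from compound 2 any more than from compound 3.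

From the compounds shown here alone, it remains open whether a plain amine such as pyrrolidin-1-yl, a methyl ester of the carboxylic acid, or a longer chain ending in hydroxy would move the number beyond the scatter. It is also open whether the carboxylic acid or the ring is what separates compound 2 from compound 3, since these two groups always travel together in the compounds shown.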